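Aryl substituent variation, from compound 3 to compound 4

This account rests on a few compounds, and the source may have more. Where it says the series, first, only, none or still open, it means among the compounds named here.

Compound 1 `COC1Cc2c(csc2-c2ccc(C)cc2)C2(CCN(Cc3ccccc3)CC2)O1` gives 2 nM in an assay on membranes from brain for displacement of a labelled ligand from Sigma non-opioid intracellular receptor 1 (Cavia porcellus), read by scintillation counting, with a stated time of 120 min; a lower number here means a stronger inhibitor, a higher number a weaker inhibitor. Compound 2 `COC1Cc2c(csc2-c2ccc([N+](=O)[O-])cc2)C2(CCN(Cc3ccccc3)CC2)O1` gives 1 nM in this assay, and compound 3 `COC1Cc2c(csc2-c2ccc(C(C)=O)cc2)C2(CCN(Cc3ccccc3)CC2)O1` gives 1.6 nM in this assay. Compound 3 thus stands second highest of the three numbers, with compound 1 nearest and compound 2 furthest, each gap within the scatter. Compound 4 `COC1Cc2c(csc2-c2ccc(-c3ccccc3)cc2)C2(CCN(Cc3ccccc3)CC2)O1` differs from compound 3 by phenyl in place of acetyl on an aromatic carbon. Going by the values given here, the steps that bear on this exchange at the same aromatic carbon are a 2.0-fold lower number from compound 1 to compound 2 (0.30 log units; within the scatter), a 1.3-fold lower number from compound 1 to compound 3 (0.10 log units; within the scatter) and a 1.6-fold higher number from compound 2 to compound 3 (0.20 log units; within the scatter), none of them beyond the scatter. A further exchange at that place is therefore expected to give a 1.9-fold higher number from compound 3 to compound 4 (0.27 log units; within the scatter) in this assay, no step beyond the scatter. Compound 4 is estimated at 3 nM, with a range from 0.8 nM to 12 nM.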

Compound 4, inhibition constant: 30 nM
Beside the measured number, compound 4's estimate is 10-fold (1.00 log units) below it; the whole stated range lies below it.
By their numbers in this assay, from the lowest: compounds 2, 3 and 1 (each within the scatter of the next); then compound 4.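

Methyl, nitro and acetyl at this aromatic carbon, para to a large group, stand within the scatter of one another, whereas phenyl moves the number beyond the scatter in this assay against acetyl (a 19-fold higher number from compound 3 to compound 4 (1.27 log units; beyond the scatter)), nitro (a 30-fold higher number from compound 2 to compound 4 (1.48 log units; beyond the scatter)) and methyl (a 15-fold higher number from compound 1 to compound 4 (1.18 log units; beyond the scatter)). Of these four groups, only phenyl carries a ring, so the position does separate it from the other three. Nothing measured here accounts for this loss.

Going by these compounds, whether the aromatic ring as such sets the step remains open. A cyclohexyl ring, a pyridyl ring or a butyl chain at the same carbon would bear on that question.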